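Notes on the phenyl substituent series, compound 3 to compound 4

The source may report more compounds than this note shows. Statements on the series, on what has been measured and on what is new or still open speak of the compounds shown alone.

Measured so far in a functional assay on A549 cells (Homo sapiens) for inhibition, read by MTT assay, with a stated time of 24 h; a lower number here means a stronger inhibitor, a higher number a weaker inhibitor:
compound 1 `CC1(C)[C@H]2CC[C@]1(C)N(Cc1cn(-c3cccc(F)c3)nn1)C(=O)C2` gives 180 nM
compound 2 `CC1(C)[C@H]2CC[C@]1(C)N(Cc1cn(-c3ccc(O)cc3)nn1)C(=O)C2` gives 140 nM
compound 3 `CC1(C)[C@H]2CC[C@]1(C)N(Cc1cn(-c3ccccc3)nn1)C(=O)C2` gives 70 nM

Compound 3 has the lowest number of the three, but only its gap to compound 1 lies beyond the scatter: a 2.6-fold lower number from compound 1 to compound 3 (0.41 log units; beyond the scatter). The other two steps, a 1.3-fold lower number from compound 1 to compound 2 (0.11 log units; within the scatter) and a 2.0-fold lower number from compound 2 to compound 3 (0.30 log units; within the scatter), are within it, so no order between compound 2 and compound 3 can be read from these numbers.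

Compound 4 `Cc1cccc(-n2cc(CN3C(=O)C[C@@H]4CC[C@@]3(C)C4(C)C)nn2)c1` differs from compound 3 in one place: methyl in place of hydrogen on an aromatic carbon. For the measured compounds named here, the only step that bears on this change is the one from compound 1 to compound 3, in which fluoro at the same carbon of the phenyl was replaced by hydrogen and the number fell modestly, a 2.6-fold lower number from compound 1 to compound 3 (0.41 log units; beyond the scatter). Methyl entering at that carbon therefore points the other way: a small rise in this assay is expected, likely at the edge of the scatter, a 1.7-fold higher number from compound 3 to compound 4 (0.23 log units; within the scatter). Going by the values given here, no measured compound carries methyl on this ring, so the expectation is loosely held. Compound 4 is expected to give about 120 nM in this assay, with a range from 55 nM to 280 nM.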

Compound 4, half-maximal inhibitory concentration: 50 nM
Estimate against measurement, compound 4: 2.4-fold (0.38 log units) above; measured number below the stated range.
By their numbers in this assay, from the lowest: compounds 4, 3, 2 and 1 (each within the scatter of the next, the first and the last beyond it).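

In this assay, methyl at this aromatic carbon cannot be told apart from hydrogen (a 1.4-fold lower number from compound 3 to compound 4 (0.15 log units; within the scatter)), so the rise seen with fluoro at the same carbon does not carry over to every group placed there. Methyl and fluoro themselves separate at this carbon (a 3.6-fold lower number from compound 1 to compound 4 (0.56 log units; beyond the scatter)), and 3-methylphenyl also separates from 4-hydroxyphenyl on the aromatic nitrogen (a 2.8-fold lower number from compound 2 to compound 4 (0.45 log units; beyond the scatter)), giving compound 4 a modest lead over both compounds while it stays level with compound 3. No evidence at hand accounts for these differences.

Still open, on these data alone, is whether this carbon accepts a larger or differently built group, such as ethyl, methoxy, an amine or a carboxylic acid, as it accepts methyl. Also open, as far as these compounds go, is how methyl behaves at the other carbons of the phenyl.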